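Working notes: one open analogue in a small series

The source may report more compounds than this note shows. Statements on the series, on what has been measured and on what is new or still open speak of the compounds shown alone.

Measured so far in a functional assay on CCRF-CEM cells (Homo sapiens) for cytotoxicity, with a stated time of 72 h; a lower number here means a stronger inhibitor, a higher number a weaker inhibitor:
compound 1, `O=C1/C(=C/c2ccc(Cl)cc2)CCC/C1=C\c1ccc([N+](=O)[O-])cc1`, gives 8180 nM
compound 2, `O=C1/C(=C/c2ccc(Cl)cc2)CCC/C1=C\c1ccccc1[N+](=O)[O-]`, gives 1750 nM
compound 3, `O=C1/C(=C/c2ccccc2)CCC/C1=C\c1ccc([N+](=O)[O-])cc1`, gives 9320 nM

Compound 1 and compound 3 differ in one place:
hydrogen in place of chloro on an aromatic carbon
That step is a 1.1-fold higher number from compound 1 to compound 3 (0.06 log units; within the scatter). Compound 2 has the same atoms as compound 1, joined differently; the difference between the two cores is not broken down here. Compound 2 stands lowest of the three, with both other numbers beyond the scatter from it.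

Compound 4, `O=C1/C(=C/c2ccccc2)CCC/C1=C\c1ccccc1[N+](=O)[O-]`, awaits measurement in this assay. It differs from compound 2 as follows:
hydrogen in place of chloro on an aromatic carbon
The place is the same, word for word, as for the earlier change. Because the earlier step of a 1.1-fold higher number from compound 1 to compound 3 (0.06 log units; within the scatter) stays within the scatter, the expected step from compound 2 to compound 4 is a 1.1-fold higher number from compound 2 to compound 4 (0.04 log units; within the scatter), likewise small. Compound 4 is therefore estimated at 1900 nM in this assay, expected between 900 nM and 4000 nM.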

Compound 4, half-maximal inhibitory concentration: 925 nM
Compound 4: middle estimate off by 2.1-fold (0.31 log units), on the high side, and the stated range covers the measured number.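

The change from 4-chlorophenyl to phenyl gives a 1.9-fold lower number from compound 2 to compound 4 (0.28 log units; within the scatter) in this assay, and set beside the earlier step it reads alike on the two cores: the same change on two cores in this assay, a 1.1-fold higher number (0.06 log units; within the scatter) from compound 1 to compound 3 and a 1.9-fold lower number (0.28 log units; within the scatter) from compound 2 to compound 4, 2.2-fold (0.33 log units) apart, within the scatter of two such steps. Across these two pairs, then, the change carries from one core to the other with neither step nor gap beyond the scatter. Two pairs do not show that the change stays this small on any other core, and a real difference between the cores smaller than the scatter would go unseen here.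

Open, from the compounds shown here alone, is whether another group on that aromatic carbon, such as methoxy or an amine, would shift the number beyond the scatter. Also open, going by these compounds, is how the number responds when a carboxylic acid takes the place of the nitro group.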